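The compounds below may be only part of what the source reports. "The series", "measured", "known", "first", "only" and "open" are said of these compounds alone.

Compound 1 `O=C(O)CC/C=C\CC1COC(c2ccc(C(F)(F)F)cc2)OC1c1cccnc1` gives 1780 nM
Compound 2 `O=C(O)CC/C=C\CC1COC(c2cccnc2)OC1c1cccnc1` gives 759 nM
Compound 3 `COc1ccc(OC(C)(C)C2OCC(C/C=C\CCC(=O)O)C(c3cccnc3)O2)cc1` gives 302 nM

In a functional assay for inhibition, with Homo sapiens as the target (on this read-out lower numbers stand for tighter binding and higher numbers for weaker binding), compound 3 holds the lowest of the three numbers, and the numbers of compound 2 and compound 1 both lie above it, beyond the scatter. Compound 4 `CC(C)(Oc1ccccc1Br)C1OCC(C/C=C\CCC(=O)O)C(c2cccnc2)O1` has not yet been measured. Its difference from compound 3 is 2-bromophenyl in place of 4-methoxyphenyl on an oxygen on a saturated carbon and amounts to 2-bromophenyl in place of 4-methoxyphenyl on an oxygen on a saturated carbon. Going by the values given here, no measured step touches this group. Among the compounds with values here, the only step available, a 2.3-fold lower number from compound 1 to compound 2 (0.37 log units; beyond the scatter), is modest and concerns another substituent, on a saturated ring carbon, so it offers no guide to size or direction here. No change beyond the scatter is therefore expected, although the range has to stay wide. The estimate is a 1.1-fold lower number from compound 3 to compound 4 (0.03 log units; within the scatter) and it means no expected shift of any weight. For compound 4 the estimated value is 280 nM with an expected range from 90 nM to 870 nM.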

Compound 4, dissociation constant: 63.1 nM
Estimate against measurement, compound 4: 4.4-fold (0.65 log units) above; the measured number lies below the stated range.
By their numbers in this assay, from the lowest: compound 4; then compound 3; then compound 2; then compound 1.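

In this assay, going by these compounds alone, the group on the oxygen on a saturated carbon proves able to move the number, with 2-bromophenyl in place of 4-methoxyphenyl giving a 4.8-fold lower number from compound 3 to compound 4 (0.68 log units; beyond the scatter) as the only measured change at this position. The entering group has no hydrogen-bond acceptor where the leaving group has one, so an acceptor in this group is not needed to reach the lower number of compound 4. No measurement shown accounts for the step, so its cause remains unknown.

The step changes both the substituent and its printed ring number, so the compounds shown do not separate the effect of bromine from that of its location, a question that 4-bromophenyl and 2-methoxyphenyl would address. Also open, going by these compounds, is how plain phenyl or 2-chlorophenyl would compare at this position.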